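Replacing the Hydroxy of Compound 1 with Nitro

The compounds below may be only part of what the source reports. "The series", "measured", "known", "first", "only" and "open" are said of these compounds alone.

Measured so far:
Compound 1, `Cc1ccc(C(=O)N/N=C/c2ccccc2O)c(O)c1`: 1020 nM
Compound 2, `Cc1ccc(C(=O)N/N=C/c2ccc(Cl)cc2)c(O)c1`: 12300 nM
Compound 3, `Cc1ccc(C(=O)N/N=C/c2cc(Cl)cc(Cl)c2O)c(O)c1`: 1510 nM

The three compounds share a common core and were measured in a functional assay (Mus musculus, strain BALB/C) for inhibition, read by MTT assay, with stated times of 24 h and 72 h; on this read-out higher numbers stand for weaker inhibition and lower numbers for stronger inhibition. Among them compound 1 has the lowest number, but its gap to compound 3 lies within the scatter, so the two cannot be ranked against each other. Compound 2, by contrast, sits well beyond the scatter above compound 1; compound 2 differs from compound 1 in more than one place, so no single step can be read from that pair.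

Compound 4, `Cc1ccc(C(=O)N/N=C/c2ccccc2[N+](=O)[O-])c(O)c1`, has not yet been measured. It differs from compound 1 as follows: nitro in place of hydroxy on an aromatic carbon. Going by the values given here, no pair of measured compounds isolates this change, so there is no measured step to lean on. Among the compounds with values here, compound 2 is the only compound without the hydroxy and gives the highest number, but its chloro also differs, so it offers only weak guidance. The estimate for compound 4 is a modest rise in this assay, a 3.4-fold higher number from compound 1 to compound 4 (0.54 log units; beyond the scatter), somewhat beyond the scatter, placing compound 4 at an expected 3500 nM, with a range from 1200 nM to 10000 nM.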

Compound 4, half-maximal inhibitory concentration: > 100000 nM
Compound 4 ended at the assay's limit; the forecaster's own chance of this, stated with the estimate: 5%; middle value at least 28-fold (1.45 log units) away from the limit.
By their numbers in this assay, from the lowest: compounds 1 and 3 (each within the scatter of the next); then compound 2. At a limit, above all of these: compound 4.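

Nitro in place of hydroxy on an aromatic carbon, ortho to a large group, gives an at least 98-fold higher number from compound 1 to compound 4 (1.99 log units; beyond the scatter), and this is the first step in the set that isolates a single change at this position. The earlier compounds shown here offered no such pair, whereas this one shows that this swap alone is enough to carry the number far beyond the scatter. Compound 4 gives > 100000 nM, which is a limit of the assay and not a number: the limit of > 100000 nM in this assay, at which 1 of the 4 values shown sits.

The compounds shown leave open whether the rise follows from the hydroxy leaving or from the nitro entering, since the one step changes both at once. An amine, a methoxy or a plain hydrogen on this same aromatic carbon would tell these two readings apart.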